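The source may report more compounds than this note shows. Statements on the series, on what has been measured and on what is new or still open speak of the compounds shown alone.

Measured so far in an ADME assay on BV-2 cells (Mus musculus) for cytotoxicity, with a stated time of 24 h, tested at 10 uM; a lower number here means a stronger effect, a higher number a weaker effect of the compound at the concentration tested:
compound 1 `COc1cccc(S(=O)(=O)/C=C/c2ccncc2)c1` gives 84.3%
compound 2 `COc1ccc(S(=O)(=O)/C=C/c2ccncc2)cc1` gives 71%
compound 3 `COc1cccc(S(=O)(=O)/C=C/c2cncnc2)c1` gives 100%

Compound 2 has the lowest number of the three in this assay, with compound 1 its nearest neighbour and compound 3 the furthest. How the core of compound 1 differs from the core of compound 2 is not broken down here. Compound 4 `COc1ccc(S(=O)(=O)/C=C/c2cncnc2)cc1` has not yet been measured in this assay. It differs from compound 2 by pyrimidin-5-yl in place of pyridin-4-yl on a double-bonded chain carbon bound to a double-bonded chain carbon. The same change, (pyrimidin-5-yl in place of pyridin-4-yl on a double-bonded chain carbon bound to a double-bonded chain carbon), has been measured once: a number 15.7 percentage points higher from compound 1 to compound 3 (beyond the scatter). Within the data shown here, a step of similar size is expected from compound 2 to compound 4, namely a number 15 percentage points higher from compound 2 to compound 4 (beyond the scatter), because the single measured step of a number 15.7 percentage points higher from compound 1 to compound 3 (beyond the scatter) went upward beyond the scatter. Compound 4 is therefore estimated at 86%, within a range from 72% to 100%.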

Compound 4, a percentage reported as activity, at one concentration (the size of the read-out at that concentration, not a potency): 100%
Compound 4: the middle estimate sits 14 percentage points below what was measured; measured number inside the range.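

Putting pyrimidin-5-yl in place of pyridin-4-yl gives, in this assay, a number 29 percentage points higher from compound 2 to compound 4 (beyond the scatter). Set beside the earlier step, the change goes the same way on both cores, and the two sizes cannot be told apart: the same change on two cores in this assay, a number 15.7 percentage points higher (beyond the scatter) from compound 1 to compound 3 and a number 29 percentage points higher (beyond the scatter) from compound 2 to compound 4, 13.3 percentage points apart, within the scatter of two such steps This shows that the change carries over between these two cores, but it does not show that it would carry to any other core, and it does not explain why the number rises.

The compounds shown leave open how an amine on the double-bonded chain carbon would behave in place of either ring. They also leave open what a carboxylic acid in place of the methoxy group would do.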